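A few compounds are considered here, and "the series" means these few. Any claim that something is new, unique, unknown or untested is made for them only; others in the source may bear on it.

Measured so far in a physicochemical assay for pharmacokinetics; a higher number here means that the compound lasts longer, a lower number that the compound disappears faster:
- compound 1 `O=C(NCc1cccc(Br)c1)N1C(=O)c2ccccc2S1(=O)=O`: > 166 h
- compound 2 `O=C(c1ccccc1)N1C(=O)c2ccccc2S1(=O)=O`: > 166 h
- compound 3 `O=C(c1ccccc1)N1Cc2ccccc2S1(=O)=O`: > 166 h

Each of these entries is a limit of this assay and not a number. Compound 1 stands at > 166 h, which is a limit. The series as a whole offers only (the limit of > 166 h in this assay, at which 3 of the 3 values shown sit), so the three compounds cannot be ranked against one another. Among the compounds with values here, no pair among them differs in a single place, so no measured step is available either.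

Compound 4 `COc1ccccc1CNC(=O)N1C(=O)c2ccccc2S1(=O)=O` keeps the core of compound 1 and changes one group: 2-methoxyphenyl in place of 3-bromophenyl on a saturated chain carbon bound to an amide-type nitrogen. This puts 2-methoxyphenyl in place of 3-bromophenyl on a saturated chain carbon bound to an amide-type nitrogen.

No step beyond the usual scatter is expected in this assay, and neither direction is favoured. That expectation rests on (the limit of > 166 h in this assay, at which 3 of the 3 values shown sit), shared by compound 1, compound 2 and compound 3 despite their different structures. Another report as a limit is expected to be the likeliest outcome. The estimated step is a step that the limit leaves unreadable from compound 1 to compound 4, which is expected to stay within the scatter. For compound 4 the estimate is 200 h, with an expected range of 100 h to 400 h.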

Compound 4, half-life: > 166 h
Compound 4: a limit, no number; the forecaster's own chance of this, stated with the estimate: 75%; the middle value does not contradict the limit.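

No step can be read from compound 1 to compound 4 because both entries are limits and not numbers, as are those of the whole series: the limit of > 166 h in this assay, at which 4 of the 4 values shown sit.

The compounds shown leave open how the four rank in this assay and whether 2-methoxyphenyl in place of 3-bromophenyl changes the half-life at all.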